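The compounds below may be only part of what the source reports. "The series", "measured", "known", "first", "only" and "open" are said of these compounds alone.

In a functional assay on HCT-116 cells (Homo sapiens) for antiproliferative activity, read by MTT assay, with a stated time of 72 h (a higher number here means a weaker inhibitor, a lower number a stronger inhibitor), compound 1 (`CC(C)(C)NC(=O)CCc1cccc2c1B(O)OC2`) gives > 100000 nM as a limit of the assay and not a number. Compound 2 (`O=C(CCc1cccc2c1B(O)OC2)NCc1ccccc1`) gives > 100000 nM as a limit too. Compound 3 (`O=C(CCc1cccc2c1B(O)OC2)Nc1nccs1`) gives > 100000 nM as a limit as well. All three therefore stand at the same place (the limit of > 100000 nM in this assay, at which 3 of the 3 values shown sit) and none has a numerical value. Compound 4 (`O=C(CCc1cccc2c1B(O)OC2)Nc1ccc(Br)cc1`) keeps the core of compound 1 and carries 4-bromophenyl in place of tert-butyl on an amide-type nitrogen. Going by the values given here, three measured steps bear on this change (a step that the two limits leave unreadable from compound 1 to compound 2) and (a step that the two limits leave unreadable from compound 1 to compound 3) and (a step that the two limits leave unreadable from compound 2 to compound 3), so no size can be carried over from them. In this assay only a small move toward stronger inhibition is expected, if any, and the result may again be only a limit. The estimated step is (an at least 1.1-fold lower number from compound 1 to compound 4 (0.04 log units; that floor lies within the scatter)) and it remains uncertain. The estimate for compound 4 is 90000 nM as the middle, with 30000 nM and 150000 nM as the ends of the expected range.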

Compound 4, half-maximal inhibitory concentration: 46000 nM
Estimate against measurement, compound 4: 2.0-fold (0.29 log units) above; the range from low to high includes it.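

Going by these compounds alone, with 4-bromophenyl on the amide-type nitrogen, compound 4 gives 46000 nM in this assay, the first number.

Compound 1, compound 2 and compound 3 stay at a limit of the assay and not a number: the limit of > 100000 nM in this assay, at which 3 of the 4 values shown sit.

The change can therefore be read against each of them, and it gives an at least 2.1-fold lower number from compound 1 to compound 4 (0.33 log units; beyond the scatter), an at least 2.1-fold lower number from compound 2 to compound 4 (0.33 log units; beyond the scatter) and an at least 2.1-fold lower number from compound 3 to compound 4 (0.33 log units; beyond the scatter). So 4-bromophenyl registers in this assay where tert-butyl, benzyl and 1,3-thiazol-2-yl do not, although the steps among compounds 1, 2 and 3 still cannot be read.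

The compounds shown leave open whether these steps belong to the bromine or to the phenyl ring, which an unsubstituted phenyl or a 4-chlorophenyl on the same nitrogen would separate. Going by these compounds, the true size of each step also stays open, since each is only a floor set by a limit.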